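The source may hold more compounds than are shown below. What is called first, only, known or untested is meant among the compounds shown, and "the series" means these compounds.

Measured so far:
- Compound 1 `OCC#CCSc1cnc2ccccc2c1[Se]CC#CCO`: 26.6 ug/mL
- Compound 2 `C#CCSc1cnc2ccccc2c1[Se]CC#CCO`: 3.3 ug/mL

Compound 2 stands lowest of the two numbers measured in a functional assay on SW707 cells (Homo sapiens) for cytotoxicity, read by sulforhodamine B assay, with a stated time of 72 h; a higher number here means a weaker inhibitor, a lower number a stronger inhibitor; its nearest neighbour is compound 1, whose number is higher by an 8.1-fold lower number from compound 1 to compound 2 (0.91 log units; beyond the scatter), a change that came from putting a hydrogen in place of a hydroxymethyl on a triple-bonded carbon.

Compound 3 `CSc1cnc2ccccc2c1[Se]CC#CCO` is not yet measured. It differs from compound 2 in one place: hydrogen in place of ethynyl on a saturated chain carbon bound to a sulfur. Cut one bond further out, this reads as propargylsulfanyl to methylsulfanyl.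

Going by the values given here, only one measured step bears on this change, and only loosely. From compound 1 to compound 2 the sulfur-side chain was shortened at its tip and the number fell by an 8.1-fold lower number from compound 1 to compound 2 (0.91 log units; beyond the scatter). Among the compounds with values here, the step to compound 3 shortens the same chain further, taking the whole ethynyl away, but no measured pair shows what that does. Within the data shown here, with a single, different step as the only guide, the expected step in this assay is a 1.1-fold lower number from compound 2 to compound 3 (0.04 log units; within the scatter), within the scatter, and the range is wide.

Compound 3 is therefore expected to give about 3 ug/mL in this assay, between 1 ug/mL and 9 ug/mL.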

Compound 3, concentration for 50% inhibition: 3.4 ug/mL
Estimate against measurement, compound 3: 1.1-fold (0.05 log units) below; low and high end bracket the measured number.
By their numbers in this assay, from the lowest: compounds 2 and 3 (each within the scatter of the next); then compound 1.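

In this assay, the whole ethynyl can go from the saturated chain carbon bound to the sulfur with no visible effect, since the number shows a 1.0-fold higher number from compound 2 to compound 3 (0.01 log units; within the scatter) and that step lies within the scatter. Propargylsulfanyl and methylsulfanyl therefore cannot be told apart here, so the triple bond of compound 2 is not needed for its number in this assay, and the only clear difference among these three compounds is that compound 1 stands apart, with a 7.8-fold lower number from compound 1 to compound 3 (0.89 log units; beyond the scatter) matching in size the earlier step to compound 2. Nothing measured on these compounds accounts for why the short chains read alike or why the chain of compound 1 gives the higher number.

The compounds shown leave open whether that higher number follows from the length of the chain on sulfur or from its hydroxyl, a question that a saturated butyl chain, or a chain ending in an amine or a carboxylic acid, could help to separate. Going by these compounds, the chain on selenium is the same in all three compounds, so how much it contributes to these numbers also remains unknown.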